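This account rests on a few compounds, and the source may have more. Where it says the series, first, only, none or still open, it means among the compounds named here.

Measured so far in a functional assay on HCT-116 cells (Homo sapiens) for cytotoxicity, read by sulforhodamine B assay, with a stated time of 48 h, tested at 0.1 uM; on this read-out lower numbers stand for a stronger effect and higher numbers for a weaker effect at the one concentration tested:
compound 1 `COc1ccc(C(=O)/C=C/c2cc(-c3cc(OC)c(OC)c(OC)c3)n[nH]2)cc1OC` gives 100%
compound 2 `COc1cc(-c2cc(/C=C/C(=O)c3ccc(F)c(F)c3)[nH]n2)cc(OC)c1OC` gives 102%

Compound 1 stands lowest of the two numbers in this assay; the nearest, compound 2, lies a step of a number 2 percentage points higher from compound 1 to compound 2 (within the scatter) away, within the scatter. Compound 3 `COc1cc(C(=O)/C=C/c2cc(-c3cc(OC)c(OC)c(OC)c3)n[nH]2)cc(OC)c1OC` differs from compound 1 by methoxy in place of hydrogen on an aromatic carbon. Within the data shown here, no measured step covers this change; the only recorded step, a number 2 percentage points higher from compound 1 to compound 2 (within the scatter), concerns another change and stayed within the scatter. Both measured numbers sit close together at this concentration, so no step beyond the scatter is expected in this assay, and the expected step of a number 1 percentage points lower from compound 1 to compound 3 (within the scatter) from compound 1 to compound 3 is flat. Compound 3 is estimated at 99%, range 88% to 110%.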

Compound 3, a percentage reported as activity, at one concentration (the size of the read-out at that concentration, not a potency): 104%
Estimate against measurement, compound 3: 5 percentage points below, and the stated range covers the measured number.
By their numbers in this assay, from the lowest: compounds 1, 2 and 3 (each within the scatter of the next).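

In this assay, methoxy in place of hydrogen on an aromatic carbon, ortho to a methoxy group and meta to a large group, gives a number 4 percentage points higher from compound 1 to compound 3 (within the scatter). At this concentration, this position therefore accepts the added methoxy with no step beyond the scatter, as the change on the carbonyl carbon did in compound 2. No available evidence bears on this result.

Still open, going by these compounds, is whether an amine or a carboxylic acid at this position would give a step beyond the scatter. Also open, on these data alone, is whether compound 1 and compound 3 would separate at other concentrations.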